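The compounds below may be only part of what the source reports. "The series", "measured", "known", "first", "only" and "open" are said of these compounds alone.

Compound 3, `CCn1cnc(N)c2ncnc1-2`, carries the shared core with an ethyl chain on the aromatic nitrogen. In an assay on isolated protein (adrenal medulla) for inhibition of Dopamine beta-hydroxylase (Bos taurus) (on this read-out lower numbers stand for stronger inhibition and higher numbers for weaker inhibition), compound 3 gives > 200 ug/mL, which is a limit of the assay rather than a number. Compound 3 thus sits at the limit of > 200 ug/mL in this assay, at which 1 of the 3 values shown sits. For comparison, compound 1, `Nc1ncn(Cc2cccc(Cl)c2)c2ncnc1-2`, gives 2 ug/mL in this assay, and compound 2, `Cc1cccc(Cn2cnc(N)c3ncnc2-3)c1`, gives 20 ug/mL; the measured step is a 10-fold higher number from compound 1 to compound 2 (1.00 log units; beyond the scatter). Compound 4, `CCCCn1cnc(N)c2ncnc1-2`, differs from compound 3 by ethyl in place of hydrogen on a saturated chain carbon, two bonds along the chain from an aromatic nitrogen. Going by the values given here, the single measured step, a 10-fold higher number from compound 1 to compound 2 (1.00 log units; beyond the scatter), concerns an aromatic substituent and does not bear on chain extension; no measured step covers this change. Compounds 1 and 2 show that other groups in the series give numbers, so a small step downward is expected: an at least 1.3-fold lower number from compound 3 to compound 4 (0.12 log units; that floor lies within the scatter). Compound 4 is therefore estimated at 150 ug/mL, range 40 ug/mL to 400 ug/mL, with a fair chance that only a limit is reported again.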

Compound 4, half-maximal inhibitory concentration: 20 ug/mL
Compound 4: the middle estimate sits 7.5-fold (0.88 log units) above what was measured, and the stated range ends above it.
By their numbers in this assay, from the lowest: compound 1; then compounds 2 and 4 (each within the scatter of the next). At a limit, above all of these: compound 3.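

Extending the chain at this position has a readable effect: in this assay, ethyl in place of hydrogen on a saturated chain carbon, two bonds along the chain from an aromatic nitrogen, gives an at least 10-fold lower number from compound 3 to compound 4 (1.00 log units; beyond the scatter). A butyl chain on the aromatic nitrogen, with no ring, is thus enough for compound 4 to give a number. From the compounds shown here alone, the true size of the step stays unknown, since compound 3 stands at a limit: the limit of > 200 ug/mL in this assay, at which 1 of the 4 values shown sits. Still open, going by these compounds, is whether a longer chain such as hexyl lowers the number further, and how an amine or a carboxylic acid at the chain end would read.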